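The source may hold more compounds than are shown below. What is called first, only, known or untested is meant among the compounds shown, and "the series" means these compounds.

Compound 3 `Nc1scc(CN2CCN(c3ccc(F)cc3F)CC2)c1C(=O)c1ccc(Cl)cc1` stands level with its two measured relatives. In an assay on CHO cells for displacement of a labelled ligand from adenosine receptor A3 (Homo sapiens), read by scintillation counting, with a stated time of 120 min, tested at 10 uM (on this read-out higher numbers stand for more inhibition at the one concentration tested (going by the name of the read-out) and lower numbers for less inhibition), compound 3 gives 0%, compound 1 `Nc1scc(CN2CCN(c3ccc(Cl)cc3Cl)CC2)c1C(=O)c1ccc(Cl)cc1` gives 0% and compound 2 `Nc1scc(CN2CCN(c3ccc(F)cc3Cl)CC2)c1C(=O)c1ccc(Cl)cc1` gives 0%. The steps among them are flat: no change at the digits printed from compound 1 to compound 2 (within the scatter), no change at the digits printed from compound 2 to compound 3 (within the scatter) and no change at the digits printed from compound 1 to compound 3 (within the scatter). Compound 4 `Nc1scc(CN2CCN(c3c(F)cc(F)cc3F)CC2)c1C(=O)c1ccc(Cl)cc1` differs from compound 3 by fluoro in place of hydrogen on an aromatic carbon. Among the measured compounds shown here, the two closest measured steps, each a fluoro for a chloro on an aromatic carbon, moved nothing beyond the scatter, and no measured step adds a fluoro in place of hydrogen, so the expectation for this assay rests on the flat run alone. The step is therefore expected to be no change at the digits printed from compound 3 to compound 4 (within the scatter). For compound 4 the expected reading in this assay is 0%, between -10% and 12%.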

Compound 4, a percentage reported as inhibition, at one concentration (the size of the read-out at that concentration, not a potency): 0%
For compound 4 middle estimate and measured number coincide at the digits printed, within the range that was stated.
By their numbers in this assay, from the lowest: compounds 1, 2, 3 and 4 (each within the scatter of the next).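

In this assay, among the compounds shown here, a fluoro in place of hydrogen, a kind of change absent from the earlier steps, gives no change at the digits printed from compound 3 to compound 4 (within the scatter) on an aromatic carbon ortho to a large group. The 2,4,6-trifluorophenyl group likewise gives no change at the digits printed from compound 2 to compound 4 (within the scatter) against the 2-chloro-4-fluorophenyl group, and no change at the digits printed from compound 1 to compound 4 (within the scatter) against the 2,4-dichlorophenyl group. No measured evidence accounts for this flat result. As far as these compounds go, whether a methoxy group or a carboxylic acid on this ring would shift the reading stays open. With every halogen pattern shown reading alike, the compounds do not tell how this position responds to groups other than fluoro and chloro.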